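Ring-opened diamine analogue of compound 1

The source may report more compounds than this note shows. Statements on the series, on what has been measured and on what is new or still open speak of the compounds shown alone.

Measured so far:
compound 1 `CCCCCCCCCCc1ccc(-c2noc([C@@H]3CCCN3)n2)cc1`: 21%
compound 2 `CCCCCCCCCCc1ccc(-c2noc(CN3CCNCC3)n2)cc1`: 19%
compound 3 `CCCCCCCCCCc1ccc(-c2noc(CC(CN)OC(C)=O)n2)cc1`: 0%

In an assay on HeLa cells for inhibition of sphingosine-1-phosphate transporter SPNS2 (Mus musculus), read by LC-MS, tested at 2 uM (a higher number here means more inhibition at the concentration tested (going by the name of the read-out), a lower number less inhibition), compound 1 gives 21%, the highest of the three numbers. Compound 2 gives 19%, and the step of a number 2 percentage points lower from compound 1 to compound 2 (within the scatter) lies within the scatter, so the two cannot be ordered. Compound 3 gives 0%; the steps of a number 21 percentage points lower from compound 1 to compound 3 (beyond the scatter) and a number 19 percentage points lower from compound 2 to compound 3 (beyond the scatter) both lie beyond the scatter and are modest in size.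

Compound 4 `CCCCCCCCCCc1ccc(-c2noc([C@@H](N)CCCN)n2)cc1` differs from compound 1 in one place: 1,4-diaminobutyl in place of pyrrolidin-2-yl on an aromatic carbon. Going by the values given here, two measured steps bear on it. Exchanging one ring amine for another, from compound 1 to compound 2, changed nothing beyond the scatter; opening the ring to a chain that carries an acetate, from compound 1 to compound 3, cost a modest amount. Compound 4 also opens the ring, but keeps two nitrogens in the chain, so a small loss, at most a modest one, is expected, a number 8 percentage points lower from compound 1 to compound 4 (within the scatter). Compound 4 is therefore estimated at 13%, with a range from 0% to 28%.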

Compound 4, a percentage reported as inhibition, at one concentration (the size of the read-out at that concentration, not a potency): 40%
Estimate against measurement, compound 4: 27 percentage points below; measured number outside the range, above it.
By their numbers in this assay, from the lowest: compound 3; then compounds 2 and 1 (each within the scatter of the next); then compound 4.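

In this assay, opening the ring at this position does not by itself cost inhibition: 1,4-diaminobutyl in place of pyrrolidin-2-yl gives a number 19 percentage points higher from compound 1 to compound 4 (beyond the scatter) and, against (piperazin-1-yl)methyl, a number 21 percentage points higher from compound 2 to compound 4 (beyond the scatter). Open chains now span the whole range seen in the series, with a number 40 percentage points higher from compound 3 to compound 4 (beyond the scatter) on going from the acetate-bearing chain to 1,4-diaminobutyl, so the absence of a ring does not account for the low number of compound 3. Nothing available gives a reason for these steps.

The compounds shown leave open whether both amines of 1,4-diaminobutyl are needed, which a chain with only one of them, such as 1-aminobutyl or 4-aminobutyl, would test. They also leave open whether a longer diamine, such as 1,5-diaminopentyl, or the opposite configuration at the stereocentre would hold the number.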